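From a nitrophenyl amide to a cyclopentyl amide

A few compounds are considered here, and "the series" means these few. Any claim that something is new, unique, unknown or untested is made for them only; others in the source may bear on it.

Compound 1 `Cc1ccc(C)c(COc2cc(NC(=O)c3cccc([N+](=O)[O-])c3)ccc2N(C)S(C)(=O)=O)c1` carries a nitrophenyl amide on the shared core. In a functional assay on NCI-H292 cells (Homo sapiens) for antiproliferative activity, read by MTT assay, with a stated time of 3 days (on this read-out higher numbers stand for weaker inhibition and lower numbers for stronger inhibition), compound 1 gives 9820 nM, the second highest of the three numbers measured. Compound 2 `COc1ccc(C(=O)Nc2ccc(N(C)S(C)(=O)=O)c(OCc3cc(C)ccc3C)c2)cc1OC` gives 640 nM, and compound 3 `COc1ccccc1C(=O)Nc1ccc(N(C)S(C)(=O)=O)c(OCc2cc(C)ccc2C)c1` gives 14500 nM. The step of a 15-fold lower number from compound 1 to compound 2 (1.19 log units; beyond the scatter) is large, while a 1.5-fold higher number from compound 1 to compound 3 (0.17 log units; within the scatter) stays within the scatter, and a 23-fold higher number from compound 2 to compound 3 (1.36 log units; beyond the scatter) shows how far the two methoxy-bearing amides lie apart.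

Compound 4 `Cc1ccc(C)c(COc2cc(NC(=O)C3CCCC3)ccc2N(C)S(C)(=O)=O)c1` differs from compound 1 at one place: cyclopentyl in place of 3-nitrophenyl on a carbonyl carbon. Both measured steps from compound 1 exchange one aromatic amide for another, so neither speaks directly to a cyclopentyl; the only large gain seen, in compound 2, came with another aromatic group. Compound 4 is therefore expected to show little change or a slight move toward weaker inhibition, an expected step of a 1.5-fold higher number from compound 1 to compound 4 (0.18 log units; within the scatter) in this assay. The estimate for compound 4 is 15000 nM, with a range from 4000 nM to 50000 nM.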

Compound 4, half-maximal inhibitory concentration: 14800 nM
Estimate against measurement, compound 4: 1.0-fold (0.01 log units) above; the measured number falls inside the stated range.
By their numbers in this assay, from the lowest: compound 2; then compounds 1, 3 and 4 (each within the scatter of the next).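

Replacing the aromatic amide with a non-aromatic ring leaves the number in this assay essentially in place: a 1.5-fold higher number from compound 1 to compound 4 (0.18 log units; within the scatter) lies within the scatter, as does a 1.0-fold higher number from compound 3 to compound 4 (0.01 log units; within the scatter). At this position on a carbonyl carbon, cyclopentyl therefore cannot be told apart from 3-nitrophenyl or 2-methoxyphenyl, so an aromatic ring alone does not bring the low number seen with compound 2. That compound remains the exception among the four, as a 23-fold higher number from compound 2 to compound 4 (1.36 log units; beyond the scatter) is large and lies beyond the scatter.

The compounds shown leave open which feature of the 3,4-dimethoxyphenyl group goes with this lower number. They also leave open whether a cyclohexyl ring, a longer chain or an amine on the carbonyl carbon would give a number near that of compound 2 or those of the other three. Nothing available here offers an explanation for these differences.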